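The compounds below may be only part of what the source reports. "The series", "measured", "known", "first", "only" and "open" are said of these compounds alone.

Compound 1 `C#CCCCCOc1ccc2oc(=O)c(C(=O)OC)cc2c1`; compound 2 `C#CCCCCOc1ccc2cc(NC(C)=O)c(=O)oc2c1`; compound 3 `COC(=O)c1cc2cc(OCc3cccc(Cl)c3)ccc2oc1=O`.

In an assay on cells for inhibition of Amine oxidase [flavin-containing] A (Homo sapiens), read by Amplex Red, with stated times of 30 min and 45 min (a higher number here means a weaker inhibitor, a lower number a stronger inhibitor), compound 2 gives 66.8 nM. Compound 1 gives only a limit, > 10000 nM. Compound 3 likewise gives only a limit, > 10000 nM. The change from compound 1 to compound 3 is 3-chlorophenyl in place of pent-4-yn-1-yl on a saturated chain carbon bound to an oxygen on an aromatic ring, and its size is a step that the two limits leave unreadable from compound 1 to compound 3 because of the limit of > 10000 nM in this assay, at which 2 of the 3 values shown sit. The difference between the core of compound 1 and that of compound 2 is not broken down here.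

Compound 4 `CC(=O)Nc1cc2ccc(OCc3cccc(Cl)c3)cc2oc1=O` is not yet measured. It differs from compound 2 by 3-chlorophenyl in place of pent-4-yn-1-yl on a saturated chain carbon bound to an oxygen on an aromatic ring, the same change as from compound 1 to compound 3, at the same place. Since that earlier step is unreadable, no size is carried over, so a modest step is expected, a 1.8-fold higher number from compound 2 to compound 4 (0.25 log units; within the scatter). Compound 4 is therefore estimated at 120 nM in this assay, between 25 nM and 700 nM.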

Compound 4, half-maximal inhibitory concentration: 62.7 nM
Estimate against measurement, compound 4: 1.9-fold (0.28 log units) above; the measured number falls inside the stated range.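

On the core of compound 2, in this assay, 3-chlorophenyl in place of pent-4-yn-1-yl gives a 1.1-fold lower number from compound 2 to compound 4 (0.03 log units; within the scatter), so on this core the change leaves the number within the scatter. On the core of compound 1 the same change cannot be read, since compound 1 and compound 3 each give only a limit and not a number: the limit of > 10000 nM in this assay, at which 2 of the 4 values shown sit. The result therefore shows what the change does on one core only, and it does not show whether that outcome carries over to the other core.

The compounds shown leave open how a longer chain, an amine or a carboxylic acid in place of 3-chlorophenyl would read on the core of compound 2. They also leave open whether any group at this place can bring the core of compound 1 to a readable number.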